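Swapping Trifluoromethoxy for Aminomethyl on the Terminal Ring

The source may report more compounds than this note shows. Statements on the series, on what has been measured and on what is new or still open speak of the compounds shown alone.

Compound 1 `CC(=O)Nc1cccc(NC(=O)COc2ccc3c(=O)ccoc3c2)c1` gives 2500 nM in an assay on isolated protein for inhibition of Rho-associated protein kinase 1 (Homo sapiens), read by scintillation counting, radiometric assay and 33P incorporation, with a stated time of 40 min, in the presence of a further agent that is not named here; on this read-out lower numbers stand for stronger inhibition and higher numbers for weaker inhibition.
Compound 2 `O=C(COc1ccc2c(=O)ccoc2c1)Nc1cccc(NC(=O)c2ccc(OC(F)(F)F)cc2)c1` gives 869 nM in this assay.

Among the measured compounds shown here, compound 2 stands at the lowest of the two numbers in this assay, and its only neighbour is compound 1. For the measured compounds named here, the single measured step, a 2.9-fold lower number from compound 1 to compound 2 (0.46 log units; beyond the scatter), shows that replacing a methyl on the carbonyl carbon with a whole 4-(trifluoromethoxy)phenyl ring brings a modest gain.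

Compound 3 `NCc1ccc(C(=O)Nc2cccc(NC(=O)COc3ccc4c(=O)ccoc4c3)c2)cc1` differs from compound 2 in one place: aminomethyl in place of trifluoromethoxy on an aromatic carbon. The same difference, cut one bond further out, reads 4-(trifluoromethoxy)phenyl to 4-(aminomethyl)phenyl.

Going by the values given here, no measured step touches this part of the molecule. Among the compounds with values here, the one step available, from compound 1 to compound 2, concerns whether an aryl ring is present at all, not which group sits on it, so it offers no direct guide. With nothing comparable to lean on, the expectation for compound 3 is a change of no more than the scatter in this assay, in either direction, expressed as a 1.2-fold lower number from compound 2 to compound 3 (0.09 log units; within the scatter). The estimate for compound 3 is therefore 700 nM, with a wide range from 150 nM to 3000 nM.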

Compound 3, half-maximal inhibitory concentration: 532 nM
Compound 3: middle estimate off by 1.3-fold (0.12 log units), on the high side, within the range that was stated.
By their numbers in this assay, from the lowest: compounds 3 and 2 (each within the scatter of the next); then compound 1.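

In this assay, this place on the terminal ring accepts a sizeable exchange without a reading that can be told apart (a 1.6-fold lower number from compound 2 to compound 3 (0.21 log units; within the scatter)). Trifluoromethoxy, with 5 heavy atoms and 0 hydrogen-bond donors, and aminomethyl, with 2 heavy atoms and 1 hydrogen-bond donor, therefore cannot be separated on this measure, despite their different make-up. The gain from having a substituted phenyl ring in place of the methyl also appears with a second substituent (a 4.7-fold lower number from compound 1 to compound 3 (0.67 log units; beyond the scatter)), as it did with trifluoromethoxy (a 2.9-fold lower number from compound 1 to compound 2 (0.46 log units; beyond the scatter)), so it does not depend on that one group among the compounds shown. Nothing measured here accounts for why the two groups read alike.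

Going by these compounds, what remains open is whether this place stays so accepting for other groups, such as a carboxylic acid, a dimethylamino group or a longer aminoalkyl chain, or for a plain phenyl ring with only hydrogen there. The three compounds also leave open whether aminomethyl would read the same at another place on the ring.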